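Two Methoxyphenyl Ureas on Two Quinazoline-Type Cores

A few compounds are considered here, and "the series" means these few. Any claim that something is new, unique, unknown or untested is made for them only; others in the source may bear on it.

Compound 1 `COc1ccccc1NC(=O)Nc1cccc(CNc2ncnc3ccccc23)c1` and compound 2 `COc1ccc(NC(=O)Nc2cccc(CNc3ncnc4ccccc34)c2)cc1` share one core and differ only in the group on the urea nitrogen. In a functional assay on A549 cells (Homo sapiens) for antiproliferative activity, read by MTT assay (on this read-out higher numbers stand for weaker inhibition and lower numbers for stronger inhibition), compound 1 gives 30800 nM, and compound 2 gives 29300 nM. The change between them, (4-methoxyphenyl in place of 2-methoxyphenyl on an amide-type nitrogen), produced a 1.1-fold lower number from compound 1 to compound 2 (0.02 log units; within the scatter).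

Compound 3 `COc1ccccc1NC(=O)Nc1cccc(CNc2ncnc3cc(OC)c(OC)cc23)c1` carries the same 2-methoxyphenyl urea as compound 1 but on a different core; the difference between the two cores is not broken down here. In this assay compound 3 gives 15200 nM, the lowest of the three numbers, although its gap to compound 2 falls inside the usual scatter.

Compound 4 `COc1ccc(NC(=O)Nc2cccc(CNc3ncnc4cc(OC)c(OC)cc34)c2)cc1` is not yet measured. It is related to compound 3 by 4-methoxyphenyl in place of 2-methoxyphenyl on an amide-type nitrogen, the same change that separates compound 1 from compound 2, made at the same place. Because a 1.1-fold lower number from compound 1 to compound 2 (0.02 log units; within the scatter) was small, the step from compound 3 to compound 4 in this assay is expected to be small as well, estimated as a 1.1-fold lower number from compound 3 to compound 4 (0.04 log units; within the scatter). Compound 4 is therefore expected to give about 14000 nM, estimated to lie between 7000 nM and 28000 nM.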

Compound 4, half-maximal inhibitory concentration: 24500 nM
Compound 4: the middle estimate sits 1.8-fold (0.24 log units) below what was measured, within the range that was stated.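

In this assay, putting 4-methoxyphenyl in place of 2-methoxyphenyl on the amide-type nitrogen of compound 3 gave a 1.6-fold higher number from compound 3 to compound 4 (0.21 log units; within the scatter). Set beside the same change on the core of compound 1, the two steps cannot be told apart: the same change on two cores in this assay, a 1.1-fold lower number (0.02 log units; within the scatter) from compound 1 to compound 2 and a 1.6-fold higher number (0.21 log units; within the scatter) from compound 3 to compound 4, 1.7-fold (0.23 log units) apart, within the scatter of two such steps. As far as these four compounds go, the change carries from one core to the other as a step inside the usual scatter, but this does not show that the two methoxyphenyl groups are interchangeable in general, that a real difference between the two cores is absent, or that the step would stay as small on any further core.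

The compounds shown leave open how other groups on the amide-type nitrogen, such as an unsubstituted phenyl, a chlorophenyl or a simple alkyl chain, would read in this assay. They also leave open whether replacing the urea itself with a plain amide would give a step beyond the scatter on either core.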